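Replacing the dichlorinated ring with a methoxyphenyl in a chalcone

The source may report more compounds than this note shows. Statements on the series, on what has been measured and on what is new or still open speak of the compounds shown alone.

Of the compounds shown here, two of a shared core have been measured so far. Compound 1 `COc1ccc(-c2cc(/C=C/C(=O)c3ccc(N)cc3)[nH]n2)cc1` and compound 2 `COc1cc(-c2cc(/C=C/C(=O)c3ccc(Cl)c(Cl)c3)[nH]n2)cc(OC)c1OC` both carry a chain ending in a carbonyl, and both were tested in a functional assay on KM12 cells (Homo sapiens) for cytotoxicity, read by sulforhodamine B assay, with a stated time of 48 h, tested at 1 uM; a lower number here means a stronger effect, a higher number a weaker effect of the compound at the concentration tested. In this assay compound 1 gives 77%, while compound 2 gives 85%. The two numbers lie within the usual scatter of each other, so compound 2 stands together with compound 1: both show only a weak effect at the concentration used.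

Compound 3 `COc1ccc(C(=O)/C=C/c2cc(-c3cc(OC)c(OC)c(OC)c3)n[nH]2)cc1` has not yet been measured. It differs from compound 2 in one place: 4-methoxyphenyl in place of 3,4-dichlorophenyl on a carbonyl carbon. Within the data shown here, no measured step tells what such an exchange on the carbonyl carbon does, so the expectation rests on the two values alone. Since both compound 1 and compound 2 sit in the weak range, the step of no change at the digits printed from compound 2 to compound 3 (within the scatter) is expected to be small, with no clear direction beyond the scatter. Compound 3 is therefore estimated to give 85% in this assay, within a range from 65% to 100%.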

Compound 3, a percentage reported as activity, at one concentration (the size of the read-out at that concentration, not a potency): 83%
For compound 3 the middle estimate is 2 percentage points above the measured one, within the range that was stated.
By their numbers in this assay, from the lowest: compounds 1, 3 and 2 (each within the scatter of the next).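

In this assay, among these compounds, putting 4-methoxyphenyl in place of 3,4-dichlorophenyl on a carbonyl carbon gives a number 2 percentage points lower from compound 2 to compound 3 (within the scatter), the first step that changes only one place. Both groups are six-membered aromatic rings of carbon only with 8 heavy atoms, so the exchange sets two chlorine atoms against a methoxy group carrying 1 hydrogen-bond acceptor, and at the single concentration tested this difference does not separate compound 2 from compound 3. Nothing measured here speaks to why the two compounds read alike.

Compound 1 differs from compound 3 in more than one place, so it cannot show what its amino-bearing ring does on this carbonyl carbon, and this single step covers only one exchange at a concentration where the compounds shown have a weak effect. Going by these compounds, whether a carboxylic acid or a longer chain in place of the ring on this carbonyl carbon would move the read-out beyond the usual scatter remains open.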